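From chloro to trifluoromethoxy on a weakly active compound

The compounds below may be only part of what the source reports. "The series", "measured", "known", "first", "only" and "open" are said of these compounds alone.

Compounds measured in a functional assay on K562 cells (Homo sapiens) for antiproliferative activity, with a stated time of 72 h; on this read-out lower numbers stand for stronger inhibition and higher numbers for weaker inhibition
Compound 1 `OC[C@H]1O[C@@H](n2cnc3c(NCc4ccc(Cl)cc4)ncnc32)[C@H](O)[C@@H]1O` gives 218000 nM
Compound 2 `COc1cccc(CNc2ncnc3c2ncn3[C@@H]2O[C@H](CO)[C@@H](O)[C@H]2O)c1` gives > 166000 nM (a limit)
Compound 3 `OC[C@H]1O[C@@H](n2cnc3c(NCc4ccc(F)c(Cl)c4)ncnc32)[C@H](O)[C@@H]1O` gives 5500 nM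

Of the two true numbers, compound 1 has the higher, and the nearest value lies at a 40-fold lower number from compound 1 to compound 3 (1.60 log units; beyond the scatter). That step puts 3-chloro-4-fluorophenyl in place of 4-chlorophenyl. Compound 2 carries only a limit, > 166000 nM, which leaves a step that the limit leaves unreadable from compound 1 to compound 2. The remaining step is an at least 30-fold lower number from compound 2 to compound 3 (1.47 log units; beyond the scatter).

Compound 4 `OC[C@H]1O[C@@H](n2cnc3c(NCc4ccc(OC(F)(F)F)cc4)ncnc32)[C@H](O)[C@@H]1O` keeps the core of compound 1 and differs in one group: trifluoromethoxy in place of chloro on an aromatic carbon. Trifluoromethoxy stands in place of chloro on an aromatic carbon, para to a large group. Going by the values given here, no measured step makes this exact swap. The closest, a 40-fold lower number from compound 1 to compound 3 (1.60 log units; beyond the scatter), shows that a change on this same phenyl group can move the number far in this assay. The expected outcome is a 4.4-fold lower number from compound 1 to compound 4 (0.64 log units; beyond the scatter), smaller than that closest step. For compound 4 the estimated value is 50000 nM within an expected range from 8000 nM to 250000 nM.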

Compound 4, half-maximal inhibitory concentration: > 166000 nM
Compound 4 ended at the assay's limit (the forecaster's own chance of this, stated with the estimate: 25%); middle value at least 3.3-fold (0.52 log units) from the limit.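

In this assay compound 4 gives > 166000 nM, which is a limit and not a number. Going by these compounds alone, no step between compound 1 and compound 4 can be read. The compounds shown leave open how far, and in which direction, trifluoromethoxy in place of chloro moves the number.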